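A few compounds are considered here, and "the series" means these few. Any claim that something is new, unique, unknown or untested is made for them only; others in the source may bear on it.

Working notes on the hydroxamate series. Among the compounds with values here, the three compounds measured so far share a core carrying a saturated chain ending in a hydroxamic acid. Compound 1 `CCN(C(=O)c1cc(C(C)C)c(O)cc1O)c1cccc(NC(=O)CCCCCCC(=O)NO)c1` is the N-ethyl amide; compound 3 `CC(C)c1cc(C(=O)Nc2ccccc2NC(=O)CCCCCCC(=O)NO)c(O)cc1O` carries the amide hydrogen; compound 2 `CC(C)c1cc(C(=O)N(c2ccc(NC(=O)CCCCCCC(=O)NO)cc2)C(C)C)c(O)cc1O` carries isopropyl on the amide nitrogen. In a functional assay on HCT-116 cells (Homo sapiens) for inhibition, read by sulforhodamine B assay, with a stated time of 48 h (on this read-out higher numbers stand for weaker inhibition of growth and lower numbers for stronger inhibition of growth), compound 1 gives 1120 nM, the lowest number of the two numbers in hand. Compound 3 gives 4920 nM, a step beyond the scatter from compound 1. Compound 2 reaches only the limit of this assay, > 10000 nM; one of the three values sits at that limit (the limit of > 10000 nM in this assay, at which 1 of the 3 values shown sits).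

The next compound, compound 4 `CC(C)c1cc(C(=O)N(C)c2cccc(NC(=O)CCCCCCC(=O)NO)c2)c(O)cc1O`, differs from compound 1 by a single change (hydrogen in place of methyl on a saturated chain carbon bound to an amide-type nitrogen). Within the data shown here, no step between measured compounds isolates this change, so the expectation rests on compound 1 alone. The shortening from ethyl to methyl is expected to move the number in this assay little, if at all beyond the scatter, in either direction. Compound 4 is therefore estimated at 1300 nM, with a range from 500 nM to 3500 nM, an expected step of a 1.2-fold higher number from compound 1 to compound 4 (0.06 log units; within the scatter).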

Compound 4, concentration for 50% growth inhibition: 1170 nM
For compound 4 the middle estimate is 1.1-fold (0.05 log units) above the measured one; the measured number falls inside the stated range.
By their numbers in this assay, from the lowest: compounds 1 and 4 (each within the scatter of the next); then compound 3. At a limit, above all of these: compound 2.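

Cutting ethyl back to methyl at this position gives a 1.0-fold higher number from compound 1 to compound 4 (0.02 log units; within the scatter) in this assay, the first step in the series that isolates a single change, and it shows that this read-out does not separate the two groups here. Within the data shown here, compound 2 and compound 3 differ from compound 1 in more than one place, so no other step at this position can be read. No measurement in hand bears on why the number holds across this change.

The compounds shown leave open whether a propyl or benzyl group at this position would hold the number in the same way, and whether hydrogen or isopropyl would do so with the rest of compound 1 kept fixed. They also leave open whether a carboxylic acid in place of the hydroxamic acid would keep growth inhibition at this level.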